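From 4-fluorobenzyl to 4-chlorobenzyl: working notes

The compounds below may be only part of what the source reports. "The series", "measured", "known", "first", "only" and "open" are said of these compounds alone.

Compound 1 `Cc1ccc(S(=O)(=O)Oc2ccccc2/C=C(\C#N)C(=O)Nc2nnc(C)s2)cc1` gives 35%
Compound 2 `Cc1ccc(S(=O)(=O)Oc2ccccc2/C=C(\C#N)C(=O)Nc2nnc(Cc3ccccc3)s2)cc1` gives 15%
Compound 3 `Cc1ccc(S(=O)(=O)Oc2ccccc2/C=C(\C#N)C(=O)Nc2nnc(Cc3ccc(F)cc3)s2)cc1` gives 16%

All three values come from an ADME assay on HEK-293T cells (Homo sapiens) for inhibition, read by CCK-8 assay, with a stated time of 48 h, tested at 20 uM; on this read-out lower numbers stand for less inhibition of growth and higher numbers for more inhibition of growth at the one concentration tested. In this assay compound 3 gives 16%, level with compound 2 within the scatter, while both sit clearly under compound 1. Next in line is compound 4 `Cc1ccc(S(=O)(=O)Oc2ccccc2/C=C(\C#N)C(=O)Nc2nnc(Cc3ccc(Cl)cc3)s2)cc1`, which carries chloro in place of fluoro on an aromatic carbon, para to a large group.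

The closest measured precedent is a change at this same ring carbon, a number 1 percentage points higher from compound 2 to compound 3 (within the scatter), and it did not move the read-out. The larger steps, a number 20 percentage points lower from compound 1 to compound 2 (beyond the scatter) and a number 19 percentage points lower from compound 1 to compound 3 (beyond the scatter), each add a whole aromatic ring, a much bigger change than the one made here, so they bear on it only weakly. Going by the values given here, no chloro compound has been measured yet. The expected step is therefore none beyond the scatter, estimated as a number 1 percentage points higher from compound 3 to compound 4 (within the scatter). The estimate for compound 4 is 17%, with an expected range of 8% to 29%.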

Compound 4, percent growth inhibition at one concentration: 20%
Estimate against measurement, compound 4: 3 percentage points below; low and high end bracket the measured number.
By their numbers in this assay, from the lowest: compounds 2, 3 and 4 (each within the scatter of the next); then compound 1.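

At this ring carbon, para to a large group, this assay does not separate the substituents tested: chloro in place of fluoro gives a number 4 percentage points higher from compound 3 to compound 4 (within the scatter) and chloro in place of hydrogen gives a number 5 percentage points higher from compound 2 to compound 4 (within the scatter) so hydrogen, fluoro and chloro cannot be told apart here. The drop seen with an added aromatic ring on the saturated chain carbon also holds for the chlorinated ring, with 4-chlorophenyl in place of hydrogen giving a number 15 percentage points lower from compound 1 to compound 4 (beyond the scatter). Compounds 2, 3 and 4 therefore all sit clearly under compound 1. No measured evidence accounts for these numbers.

On these data alone, whether a methoxy group or an amine at this ring carbon would move the read-out beyond the scatter remains open. As far as these compounds go, the effect of a longer chain in place of the benzyl methylene also remains open.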